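Carboxy-Bearing Amine Returns to the Limit of Detection

The source may hold more compounds than are shown below. What is called first, only, known or untested is meant among the compounds shown, and "the series" means these compounds.

Compound 3 `COc1ccc(/C=C\c2cc(OC)c(OC)c(OC)c2)cc1OCc1ccc(CNCCN(C)C)cc1` gives 9400 nM in a functional assay on HeLa cells (Homo sapiens) for antiproliferative activity, read by CCK-8 assay, with a stated time of 48 h (on this read-out lower numbers stand for stronger inhibition and higher numbers for weaker inhibition), the highest of the two numbers shown. Compound 2 `COc1ccc(/C=C\c2cc(OC)c(OC)c(OC)c2)cc1OCc1ccc(C=O)cc1` gives 4800 nM, and the step of a 2.0-fold higher number from compound 2 to compound 3 (0.29 log units; within the scatter) stays within the scatter. Compound 1 `COc1ccc(/C=C\c2cc(OC)c(OC)c(OC)c2)cc1OCc1ccc(CNC(C)(C)C(=O)O)cc1` reaches only a limit, > 10000 nM. The step of an at least 1.0-fold lower number from compound 1 to compound 3 (0.02 log units; that floor lies within the scatter) thus has a floor inside the scatter, whereas an at least 2.0-fold lower number from compound 1 to compound 2 (0.31 log units; beyond the scatter) is at least modest. Compound 4 `COc1ccc(/C=C\c2cc(OC)c(OC)c(OC)c2)cc1OCc1ccc(CN[C@H](C(=O)O)[C@@H](C)O)cc1` differs from compound 3 by 1-carboxy-2-hydroxypropyl in place of 2-(dimethylamino)ethyl on an amine nitrogen. Compound 1, whose side chain likewise carries a carboxy group, accounts for (the limit of > 10000 nM in this assay, at which 1 of the 3 values shown sits), and the carboxy group entering in compound 4 points back toward that limit. Compound 4 is therefore expected to show a weakening step, a 1.6-fold higher number from compound 3 to compound 4 (0.20 log units; within the scatter). Compound 4 is estimated at 15000 nM, spanning 6000 nM to 40000 nM, quite possibly reported only as a limit.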

Compound 4, half-maximal inhibitory concentration: > 10000 nM
Compound 4 ended at the assay's limit (the forecaster's own chance of this, stated with the estimate: 60%); the middle value does not contradict the limit.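

In this assay, compound 4 is the second compound with a carboxy-bearing side chain on the amine nitrogen to end at a limit: the limit of > 10000 nM in this assay, at which 2 of the 4 values shown sit. Replacing formyl with this side chain gives an at least 2.0-fold higher number from compound 2 to compound 4 (0.31 log units; beyond the scatter), while an at least 1.0-fold higher number from compound 3 to compound 4 (0.02 log units; that floor lies within the scatter) leaves the change from 2-(dimethylamino)ethyl unsized. The step between compound 1 and compound 4 cannot be read, as both values are limits. The compounds shown leave open how a methyl ester in place of the carboxy group would read in this assay. They also leave open how a longer chain ending in a carboxylic acid would read there.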